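(Methoxycarbonyl)methyl in Place of sec-Butyl: Three Measured, One Expected

A few compounds are considered here, and "the series" means these few. Any claim that something is new, unique, unknown or untested is made for them only; others in the source may bear on it.

Compound 1 `COC(=O)C[C@H](NC(=O)OC(C)(C)C)C(=O)N(Cc1ccccc1)C1(C(=O)NCc2ccccc2)CCN(Cc2ccccc2)CC1` gives 20000 nM in a functional assay on HeLa cells (Homo sapiens) for inhibition, with a stated time of 72 h; on this read-out lower numbers stand for stronger inhibition and higher numbers for weaker inhibition.
Compound 2 `CC[C@H](C)[C@H](NC(=O)OC(C)(C)C)C(=O)N(Cc1ccccc1)C1(C(=O)NCc2ccccc2)CCN(Cc2ccccc2)CC1` gives 10000 nM in this assay.
Compound 3 `CC[C@H](C)[C@H](NC(=O)OCc1ccccc1)C(=O)N(C1CC1)C1(C(=O)NCc2ccccc2)CCN(Cc2ccccc2)CC1` gives 30000 nM in this assay.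

Compound 1 and compound 2 differ in one place, ((methoxycarbonyl)methyl in place of sec-butyl on a saturated chain carbon bound to an amide-type nitrogen and a carbonyl carbon), and this change brought a 2.0-fold higher number from compound 2 to compound 1 (0.30 log units; within the scatter). The cores of compound 2 and compound 3 differ in a way that is not broken down here; compound 3 holds the highest of the three numbers, within the scatter of compound 1 and beyond it from compound 2.

Compound 4 `COC(=O)C[C@H](NC(=O)OCc1ccccc1)C(=O)N(C1CC1)C1(C(=O)NCc2ccccc2)CCN(Cc2ccccc2)CC1` carries the same change relative to compound 3, ((methoxycarbonyl)methyl in place of sec-butyl on a saturated chain carbon bound to an amide-type nitrogen and a carbonyl carbon), at the same place. For compound 4 a step of a 1.7-fold higher number from compound 3 to compound 4 (0.22 log units; within the scatter) is expected, resting on the earlier step of a 2.0-fold higher number from compound 2 to compound 1 (0.30 log units; within the scatter), so compound 4 is estimated at 50000 nM, between 20000 nM and 120000 nM.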

Compound 4, half-maximal inhibitory concentration: 4700 nM
The estimate for compound 4 lay 11-fold (1.03 log units) above the measured number, outside the stated range (below it).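

On the core of compound 3, (methoxycarbonyl)methyl in place of sec-butyl brought a 6.4-fold lower number from compound 3 to compound 4 (0.81 log units; beyond the scatter) in this assay, whereas the same change on the core of compound 2 gave no step beyond the scatter. Set side by side, the two steps differ: the same change on two cores in this assay, a 2.0-fold higher number (0.30 log units; within the scatter) from compound 2 to compound 1 and a 6.4-fold lower number (0.81 log units; beyond the scatter) from compound 3 to compound 4, 13-fold (1.11 log units) apart, beyond the scatter of two such steps This shows that in this series the outcome of the change depends on the core, so a step read on one core cannot be carried to another, but with only one pair per core it does not show which part of the core matters or whether the difference extends to other cores.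

Going by these compounds, it remains open how a core holding only one of the differences between compound 2 and compound 3 would respond. Also open, on these data alone, is whether a carboxylic acid or an amine at the same place would follow the course of the (methoxycarbonyl)methyl group on both cores.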